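This account rests on a few compounds, and the source may have more. Where it says the series, first, only, none or still open, it means among the compounds named here.

Of the compounds shown here, three built on the shared core have been tested in an assay on isolated protein for inhibition of phosphodiesterase 4A (Sus scrofa); a higher number here means a weaker inhibitor, a lower number a stronger inhibitor. Compound 1 `COc1ccc(C(=O)Nc2ccccc2C)cc1OC1CCCC1` gives 300 nM in this assay. Compound 2 `CCCCOc1cc(C(=O)Nc2c(F)cccc2F)ccc1OC` gives 300 nM in this assay, a value level with that of compound 1 within the usual scatter, so that these two together hold the lowest numbers of the three. Compound 3 `COc1ccc(C(=O)Nc2ccccc2Cl)cc1OC(C)=O` gives 70000 nM in this assay, a number far higher than that of compound 1 and well beyond the scatter. Among the measured compounds shown here, no two of these measured compounds differ in only one place, so no single step has been worked out among them.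

The step followed here leads from compound 1 to compound 4 `COc1ccc(C(=O)Nc2cnccn2)cc1OC1CCCC1`, which has not yet been measured in this assay. The change is pyrazin-2-yl in place of 2-methylphenyl on an amide-type nitrogen. The measured compounds offer no direct guide to it, since none carries a pyrazin-2-yl on the amide-type nitrogen; compound 3 shows only that a different alteration of the core can push the number far upward. In this assay the expected step is a 2.7-fold higher number from compound 1 to compound 4 (0.43 log units; beyond the scatter), a modest rise in the number that should lie outside the scatter. Compound 4 is therefore estimated at 800 nM in this assay, within a range from 200 nM to 4000 nM.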

Compound 4, half-maximal inhibitory concentration: 250 nM
Estimate against measurement, compound 4: 3.2-fold (0.51 log units) above; measured number inside the range.
By their numbers in this assay, from the lowest: compounds 4, 1 and 2 (each within the scatter of the next); then compound 3.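

In this assay, pyrazin-2-yl in place of 2-methylphenyl on the amide-type nitrogen gives a 1.2-fold lower number from compound 1 to compound 4 (0.08 log units; within the scatter), so this exchange leaves the number unchanged within the scatter. All three earlier compounds carry a six-membered aromatic ring of carbon only on that nitrogen, and so could not show whether such a ring is needed; compound 4 shows that, on the core of compound 1, a six-membered aromatic ring with hetero atoms and hydrogen-bond acceptors serves equally well in this assay, even though the methyl group is gone as well. Nothing at hand explains why the two groups give matching numbers.

The compounds shown leave open whether this tolerance reaches beyond aromatic rings at this position, for example to a saturated piperidine ring, a simple alkyl chain or a group carrying a carboxylic acid. They also leave open whether pyrazin-2-yl behaves the same way on other versions of the core, such as one with the butoxy chain of compound 2 in place of the cyclopentyl ether.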